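The source may hold more compounds than are shown below. What is called first, only, known or untested is meant among the compounds shown, and "the series" means these compounds.

Measured so far: compound 1 `O=C(O)CC1COc2cc(OCc3ncc(-c4ccccc4)s3)ccc21` with 5.26% in a functional assay on CHO cells for agonist activity at Free fatty acid receptor 1 (Homo sapiens), read by FLIPR and calcium flux, tested at 100 nM (a lower number here means a weaker effect, a higher number a stronger effect of the compound at the concentration tested), and compound 2 `Cc1nc(-c2cccs2)sc1COc1ccc2c(c1)OCC2CC(=O)O` with 35.2% in that assay.

Compound 2 stands at the higher of the two numbers; compound 1 lies well below it, and the gap between the two values is beyond the usual scatter. Going by the values given here, the two compounds differ in more than one place, so their values show only that compound 2 gives the stronger read-out.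

Compound 3 `Cc1nc(-c2cccc(Cl)c2)sc1COc1ccc2c(c1)OCC2CC(=O)O` follows from compound 2 by one change: 3-chlorophenyl in place of thiophen-2-yl on an aromatic carbon. The new group sits on an aromatic carbon of a five-membered aromatic ring with one nitrogen and one sulfur, two ring bonds from the ring atom that bears a methyl group. Among the compounds with values here, no measured pair shows this exact change, so the size of the step in this assay is not known from the data. A modest step in either direction, or none beyond the scatter, is expected; the account puts the expected step from compound 2 to compound 3 at a number 4.8 percentage points higher from compound 2 to compound 3 (within the scatter). For compound 3 the expected value is 40%, with a range from 15% to 65%.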

Compound 3, a percentage reported as activity, at one concentration (the size of the read-out at that concentration, not a potency): 43%
Beside the measured number, compound 3's estimate is 3 percentage points below it; the range from low to high includes it.
By their numbers in this assay, from the lowest: compound 1; then compounds 2 and 3 (each within the scatter of the next).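

In this assay, the change from thiophen-2-yl to 3-chlorophenyl gives a number 7.8 percentage points higher from compound 2 to compound 3 (within the scatter). Going by these compounds alone, this is the first single-place comparison, and it shows that this aromatic carbon, next to the ring nitrogen and next to the ring sulfur, can carry either group with the read-out staying within the scatter. The sulfur of the leaving ring is therefore not required for this read-out in this pair, and the entering chlorine and six-membered ring of carbon only bring no step beyond the scatter; no measurement at hand explains the result.

From the compounds shown here alone, what the chlorine itself contributes remains open, as does whether a plain phenyl, a 3-methoxyphenyl or a pyridinyl group at this carbon would read the same. Also open, going by these compounds, is the part played by the methyl group that compound 2 and compound 3 share, which an ethyl group or a hydrogen in its place would test.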